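A fluorophenoxy group on a shared diamine core

The source may report more compounds than this note shows. Statements on the series, on what has been measured and on what is new or still open speak of the compounds shown alone.

Compound 3 `COc1ccc(Sc2nc3cc(N)cc(N)c3nc2-c2ccccc2)cc1` carries a (4-methoxyphenyl)sulfanyl group on an aromatic carbon of its core. In a functional assay on SF-539 cells (Homo sapiens) for inhibition, read by sulforhodamine B assay, with a stated time of 48 h (on this read-out higher numbers stand for lower toxicity in this test and lower numbers for higher toxicity in this test), compound 3 gives only the limit < 100000 nM and no number. Compound 2 `CCOC(=O)[C@H](CCC(=O)O)NC(=O)c1ccc(Oc2nc3cc(N)cc(N)c3nc2-c2ccccc2)cc1` likewise reaches only a limit in this assay, namely < 100000 nM. Within the data shown here, compound 1 `Nc1cc(N)c2nc(-c3ccccc3)c(Oc3ccc(Cl)c(Cl)c3)nc2c1`, which bears 3,4-dichlorophenoxy on the same aromatic carbon, is the one compound with a measured number: in this assay compound 1 gives 64600 nM. The step that the limit leaves unreadable from compound 1 to compound 3 is therefore not readable, and the limit of < 100000 nM in this assay, at which 2 of the 3 values shown sit, shows where most of the data sit. Compound 4 `Nc1cc(N)c2nc(-c3ccccc3)c(Oc3ccc(F)cc3)nc2c1` differs from compound 3 by 4-fluorophenoxy in place of (4-methoxyphenyl)sulfanyl on an aromatic carbon. Among the measured compounds shown here, no measured step offers a readable size for this change, so the only anchor is compound 1, which gives 64600 nM in this assay with a related phenoxy group. Compound 4 is thus expected to fall near that number, an expected step that the limit leaves unreadable from compound 3 to compound 4 whose size cannot be judged against the scatter. The estimate for compound 4 in this assay is 60000 nM, expected between 20000 nM and 150000 nM.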

Compound 4, concentration lethal to 50% of the cells: 70800 nM
Compound 4: middle estimate off by 1.2-fold (0.07 log units), on the low side; the measured number falls inside the stated range.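

In this assay, among these compounds, 4-fluorophenyl in place of 3,4-dichlorophenyl on the oxygen gives a 1.1-fold higher number from compound 1 to compound 4 (0.04 log units; within the scatter), the first step at this position that can be read. Compound 1 and compound 4 thus lie within the scatter of each other, so this exchange of substituents on the phenoxy ring leaves no measurable difference in this pair. The steps that involve compound 3 still cannot be read, because compound 3 has only a limit of the assay: the limit of < 100000 nM in this assay, at which 2 of the 4 values shown sit.

The compounds shown leave open whether the sulfur link of compound 3 differs from an oxygen link when the aromatic group stays the same. They also leave open whether a nitrile or a trifluoromethyl group on the phenoxy ring would give a number outside the scatter of these two.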